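Furan for dimethylaminophenyl: outlook on cell toxicity

This account rests on a few compounds, and the source may have more. Where it says the series, first, only, none or still open, it means among the compounds named here.

Measured so far:
compound 1 `CC(C)N(Cc1cccc(OCCCCCC(=O)O)c1)C(=O)c1ccc(-c2cccc(N(C)C)c2)cc1` – > 26000 nM
compound 2 `CC(C)N(Cc1cccc(OCCCCCC(=O)O)c1)C(=O)c1ccc(-c2ccncc2)cc1` – > 26000 nM

In an ADME assay on HepG2 cells (Homo sapiens) for cytotoxicity, read by CellTiter-Glo and resazurin assay, with a stated time of 72 h (on this read-out lower numbers stand for an effect already at smaller amounts and higher numbers for an effect only at larger amounts of compound), compound 1 reaches only the limit of the assay, > 26000 nM. Compound 2 likewise stops at a limit in this assay, > 26000 nM. The step that the two limits leave unreadable from compound 1 to compound 2 therefore cannot be read; both values sit at the limit of > 26000 nM in this assay, at which 2 of the 2 values shown sit, so compound 1 stands where every measured value of the series stands, at the limit and nowhere else.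

Compound 3 `CC(C)N(Cc1cccc(OCCCCCC(=O)O)c1)C(=O)c1ccc(-c2ccco2)cc1` is not yet measured in this assay. It differs from compound 1 as furan-2-yl in place of 3-(dimethylamino)phenyl on an aromatic carbon. For the measured compounds named here, the only measured step that bears on this exchange is a step that the two limits leave unreadable from compound 1 to compound 2, which replaced the same departing group by pyridin-4-yl and gave no readable size; no measured step in this assay reports a number at all. No step beyond the scatter is therefore expected for a step that the limit leaves unreadable from compound 1 to compound 3, and compound 3 is expected most likely to return a limit once more. The expected value for compound 3 is estimated at 30000 nM, within a range of 13000 nM to 90000 nM.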

Compound 3, half-maximal effective concentration: > 26000 nM
Compound 3 gave a limit, no number; the forecaster's own chance of this, stated with the estimate: 85%; the middle value is on the limit's open side.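

In this assay no new step can be read, since compound 1, compound 2 and compound 3 all stop at the same limit, which is not a number: the limit of > 26000 nM in this assay, at which 3 of the 3 values shown sit.

The compounds shown leave open whether any exchange of the group on this aromatic carbon shifts the read-out, and at what concentration any of the three would show an effect.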